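Solubility along a small amide series: from compound 3 to compound 4

A few compounds are considered here, and "the series" means these few. Any claim that something is new, unique, unknown or untested is made for them only; others in the source may bear on it.

Of the compounds shown here, three have been measured in a physicochemical assay for solubility, in phosphate buffer, measured as kinetic solubility, with a stated time of 18 h, at pH 7.4; a higher number here means a more soluble compound, a lower number a less soluble compound. Compound 1 `O=C(Nc1cc(-c2nc3ccccc3s2)ccc1F)c1cnccc1Cl` gives 180 nM, compound 2 `O=C(Nc1ccc(F)c(-c2nc3ccccc3s2)c1)c1cnccc1Cl` gives 80 nM, and compound 3 `Cc1ccc(-c2nc3ccccc3o2)cc1NC(=O)c1cnccc1Cl` gives 510 nM. Compound 3 stands highest of the three; its gap to compound 1 and its larger gap to compound 2 both lie beyond the scatter of this assay. Among the measured compounds shown here, no two measured compounds differ in only one place, so no single change has yet been tied to a shift in solubility.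

Compound 4 `O=C(Nc1cc(-c2nc3ccccc3o2)ccc1F)c1cnccc1Cl` is the next compound, not yet measured. It differs from compound 3 by fluoro in place of methyl on an aromatic carbon. For the measured compounds named here, because compound 3 reaches 510 nM and nothing among the measured compounds isolates the effect of this one exchange, the expectation for compound 4 in this assay rests mainly on its near identity to compound 3. The step of a 1.5-fold lower number from compound 3 to compound 4 (0.16 log units; within the scatter) is expected to be small, if anything a modest fall, and probably within the scatter. Compound 4 is therefore estimated at 350 nM, with a range from 120 nM to 900 nM, pending the measurement.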

Compound 4, solubility: 130 nM
Beside the measured number, compound 4's estimate is 2.7-fold (0.43 log units) above it, within the range that was stated.
By their numbers in this assay, from the lowest: compounds 2, 4 and 1 (each within the scatter of the next, the first and the last beyond it); then compound 3.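

In this assay, among the compounds shown here, the pair of compound 3 and compound 4 gives the first reading of a single exchange: fluoro in place of methyl on an aromatic carbon, ortho to a large group and para to a group of 9 heavy atoms, comes with a 3.9-fold lower number from compound 3 to compound 4 (0.59 log units; beyond the scatter). For the compounds shown here, the two compounds differ in this one place alone and their numbers lie apart beyond the scatter, so this position is now known not to be silent in this assay, which the earlier compounds, none of them a single-change pair, could not show. Nothing measured among the compounds shown speaks to why the number moves with this exchange.

Going by these compounds, only methyl and fluoro are seen at this position, so it remains open how a group such as an amine, a methoxy group or a carboxylic acid would read there. A single pair also cannot tell whether the same exchange would give a step of similar size on another core, or whether the step depends on the rest of the molecule.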